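Pyridin-4-yl for Pyridin-3-yl on an Inactive Amide

The source may report more compounds than this note shows. Statements on the series, on what has been measured and on what is new or still open speak of the compounds shown alone.

compound 1 `O=C(NCc1ccccc1)c1cn(-c2ccccc2)nc1-c1cccnc1`: > 100000 nM
compound 2 `COc1ccc(OC(=O)c2cn(-c3ccccc3)nc2-c2cccnc2)cc1`: > 100000 nM
compound 3 `Cc1ccc(C(C)C)c(OC(=O)c2cn(-c3ccccc3)nc2-c2cccnc2)c1`: > 100000 nM

In a functional assay on HeLa cells (Homo sapiens) for cytotoxicity, read by MTT assay, with a stated time of 48 h (a higher number here means a weaker inhibitor, a lower number a stronger inhibitor), compound 1 gives > 100000 nM, which is a limit of the assay and not a number. Compound 2 also reaches only that limit. Compound 3 also reaches only that limit. The step that the two limits leave unreadable from compound 1 to compound 2 and the step that the two limits leave unreadable from compound 2 to compound 3 are therefore both unreadable, and the only firm point is the limit of > 100000 nM in this assay, at which 3 of the 3 values shown sit.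

Compound 4 `O=C(NCc1ccccc1)c1cn(-c2ccccc2)nc1-c1ccncc1` has not been measured. It differs from compound 1 by pyridin-4-yl in place of pyridin-3-yl on an aromatic carbon. Of the measured steps, none varies this part of the shared core, and none has a readable size, so no direction can be drawn from them. What the measured steps do show is that every change made so far left the value at the limit.

The step of a number no higher from compound 1 to compound 4 (the limit leaves the size open) is accordingly expected to stay within the scatter. Compound 4 is estimated at 100000 nM, with a range from 30000 nM to 300000 nM, and most likely the assay will again report only a limit.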

Compound 4, half-maximal inhibitory concentration: > 100000 nM
Compound 4: no number, only a limit; the forecaster's own chance of this, stated with the estimate: 85%; the middle value sits exactly at the limit.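

In this assay compound 4 gives > 100000 nM, which is a limit of the assay and not a number. Its step from compound 1 therefore cannot be read. The compounds shown leave open what change in structure, if any, would give a readable value: the limit of > 100000 nM in this assay, at which 4 of the 4 values shown sit.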